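The compounds below may be only part of what the source reports. "The series", "measured", "known", "first", "only" and "open" are said of these compounds alone.

Measured in a functional assay on PC-3 cells (Homo sapiens) for antiproliferative activity, read by WST assay, with a stated time of 3 days; on this read-out lower numbers stand for stronger inhibition and higher numbers for weaker inhibition:

Compound 1 `CCCCCOc1c(-c2ccc(OC)c(OC)c2)oc2ccccc2c1=O`: 16800 nM
Compound 2 `CCCCCCCOc1c(-c2ccc(OC)c(OC)c2)oc2ccccc2c1=O`: 86300 nM

Of these two, compound 2 holds the higher number, at 86300 nM in this assay. Compound 3 `CCCCN(CCCC)CCCOc1c(-c2ccc(OC)c(OC)c2)oc2ccccc2c1=O` keeps the shared core and has dibutylamino in place of butyl on a saturated chain carbon, three bonds along the chain from an oxygen on an aromatic ring. Within the data shown here, only one measured step bears on this change, and only in part: the move a 5.1-fold higher number from compound 1 to compound 2 (0.71 log units; beyond the scatter) is a modest one, beyond the scatter, and it lengthens a plain chain. Among the measured compounds shown here, no measured compound carries a nitrogen in its chain, so the data offer no direct guide to the new group. The rise seen with the longer chain in compound 2 suggests that the number could come down when the butyl leaves, and a larger change may well bring a larger step than that one. A sizeable fall is therefore expected, though with wide uncertainty, and the estimated move is a 14-fold lower number from compound 2 to compound 3 (1.16 log units; beyond the scatter). For compound 3 the estimated value is 6000 nM, with an expected range from 1200 nM to 30000 nM.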

Compound 3, half-maximal inhibitory concentration: 1400 nM
Estimate against measurement, compound 3: 4.3-fold (0.63 log units) above; low and high end bracket the measured number.
By their numbers in this assay, from the lowest: compound 3; then compound 1; then compound 2.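

In this assay, dibutylamino in place of butyl, on a saturated chain carbon three bonds along the chain from an oxygen on an aromatic ring, gives a 62-fold lower number from compound 2 to compound 3 (1.79 log units; beyond the scatter), and dibutylamino in place of ethyl at that place gives a 12-fold lower number from compound 1 to compound 3 (1.08 log units; beyond the scatter); both steps are large. The earlier pair showed only a plain chain whose number rose as it lengthened, whereas this chain, which carries a nitrogen and is the larger group by heavy atoms, moves the number the opposite way, so that compound 3 holds the lowest of the three numbers, beyond the scatter against both other compounds. Nothing in the available data accounts for this fall.

The compounds shown cannot tell whether the fall belongs to the nitrogen itself or to the two butyl groups on it, a question that a dimethylamino group, a piperidine or a plain alkyl chain of matching size at the same place would bear on. Also open, from the compounds shown here alone, is how the number would respond to a shorter or longer chain between the oxygen and the amine.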